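Moving the Methyls: From Compound 2 to Compound 4

This account rests on a few compounds, and the source may have more. Where it says the series, first, only, none or still open, it means among the compounds named here.

Compound 1, `CCCc1nc(-c2ccccc2)c(CNCCN2CCN(c3ccccc3Cl)CC2)o1`, gives 4370 nM in an assay on HEK293 cells for inhibition of Voltage-dependent T-type calcium channel subunit alpha-1G (Homo sapiens), read by patch clamp; a higher number here means a weaker inhibitor, a lower number a stronger inhibitor.
Compound 2, `CCCc1nc(-c2ccccc2)c(CNCCCN2CCN(c3cccc(C)c3C)CC2)o1`, gives 1780 nM in this assay.
Compound 3, `CCCc1nc(-c2ccccc2)c(CNCCN2CCN(c3ccc(OC)cc3)CC2)o1`, gives 9200 nM in this assay.

Compound 2 stands at the lowest of the three numbers in this assay; its nearest neighbour is compound 1, and compound 3 lies furthest from it. Among the compounds with values here, the only measured step between close relatives, a 2.1-fold higher number from compound 1 to compound 3 (0.32 log units; beyond the scatter), also concerns the aromatic ring attached to the amine nitrogen in the six-membered non-aromatic ring, but it exchanges one group for a different one rather than rearranging the same atoms. Compound 4, `CCCc1nc(-c2ccccc2)c(CNCCCN2CCN(c3ccc(C)c(C)c3)CC2)o1`, differs from compound 2 by 3,4-dimethylphenyl in place of 2,3-dimethylphenyl on an amine nitrogen in a ring. Within the data shown here, no measured pair shows what such a rearrangement does; the compounds at hand show only that altering this ring shifts the number modestly. The step from compound 2 to compound 4 in this assay is therefore expected to be small, a 1.4-fold higher number from compound 2 to compound 4 (0.15 log units; within the scatter), with its direction uncertain. Compound 4 is estimated at 2500 nM, within a range of 900 nM to 7000 nM.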

Compound 4, half-maximal inhibitory concentration: 3020 nM
Compound 4: middle estimate off by 1.2-fold (0.08 log units), on the low side, within the range that was stated.
By their numbers in this assay, from the lowest: compounds 2, 4 and 1 (each within the scatter of the next, the first and the last beyond it); then compound 3.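

In this assay the exchange of 2,3-dimethylphenyl for 3,4-dimethylphenyl amounts to a 1.7-fold higher number from compound 2 to compound 4 (0.23 log units; within the scatter). This is the first pair shown in which the same atoms are rearranged rather than one group exchanged for another, and at this place, on an amine nitrogen in a ring, the two arrangements of the methyl groups cannot be told apart by this measurement. Nothing available here bears on why the pair behaves this way.

From the compounds shown here alone, whether other groups on this aromatic ring, such as trifluoromethyl or a lone fluorine, would be equally indifferent to rearrangement remains open. The contribution of the chain joining the amine nitrogens also stays unresolved, since no pair shown differs in that chain alone, and a longer chain remains an open question as well.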